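Benzyl amide on a chlorobenzamide core: a cytotoxicity forecast

The source may hold more compounds than are shown below. What is called first, only, known or untested is meant among the compounds shown, and "the series" means these compounds.

Measured compounds in a functional assay on HepG2 cells (Homo sapiens) for cytotoxicity, read by MTT assay, with a stated time of 48 h; a higher number here means a weaker inhibitor, a lower number a stronger inhibitor:
compound 1, `O=C(CSc1nc2ccc(NC(=O)CCl)cc2s1)NCc1ccccc1`, gives 1100 nM
compound 2, `CNC(=O)CSc1nc2ccc(NC(=O)CCl)cc2s1`, gives 1900 nM
compound 3, `CNC(=O)CSc1nc2ccc(NC(=O)c3ccc(Cl)cc3)cc2s1`, gives 15300 nM

Compound 2 and compound 1 share one core and differ in a single place, described as phenyl in place of hydrogen on a saturated chain carbon bound to an amide-type nitrogen. In this assay this change made a 1.7-fold lower number from compound 2 to compound 1 (0.24 log units; within the scatter), so the two numbers are not distinguished by the assay.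

Compound 3 stands on a different core. Its difference from compound 2 is counted as 4-chlorophenyl in place of chloromethyl on a carbonyl carbon, and in this assay that change made an 8.1-fold higher number from compound 2 to compound 3 (0.91 log units; beyond the scatter). Compound 3 holds the highest number of the three, and its steps to both compound 2 and compound 1 lie beyond the scatter.

Compound 4, `O=C(CSc1nc2ccc(NC(=O)c3ccc(Cl)cc3)cc2s1)NCc1ccccc1`, has not been measured. It differs from compound 3 by phenyl in place of hydrogen on a saturated chain carbon bound to an amide-type nitrogen, which is the same change that leads from compound 2 to compound 1, at a place described in the same words. On that basis, and on the weakness of the earlier step, the number for compound 4 in this assay is expected to sit close to that of compound 3, with a step estimated at a 1.6-fold lower number from compound 3 to compound 4 (0.21 log units; within the scatter). For the measured compounds named here, the estimate for compound 4 in this assay is 9500 nM, with an expected range from 3000 nM to 25000 nM, since the only precedent, the step from compound 2 to compound 1, was within the scatter.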

Compound 4, half-maximal inhibitory concentration: 25400 nM
Estimate against measurement, compound 4: 2.7-fold (0.43 log units) below; the whole stated range lies below it.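

In this assay, the change from methylcarbamoyl to benzylcarbamoyl gave a 1.7-fold higher number from compound 3 to compound 4 (0.22 log units; within the scatter), and although each of the two steps for this change lies within the scatter on its own, they do not agree with each other across the two cores: the same change on two cores in this assay, a 1.7-fold lower number (0.24 log units; within the scatter) from compound 2 to compound 1 and a 1.7-fold higher number (0.22 log units; within the scatter) from compound 3 to compound 4, 2.9-fold (0.46 log units) apart, beyond the scatter of two such steps

The other change, 4-chlorophenyl in place of chloromethyl on a carbonyl carbon, gave a 23-fold higher number from compound 1 to compound 4 (1.36 log units; beyond the scatter), so it raised the number on both cores, but not by the same amount: the same change on two cores in this assay, an 8.1-fold higher number (0.91 log units; beyond the scatter) from compound 2 to compound 3 and a 23-fold higher number (1.36 log units; beyond the scatter) from compound 1 to compound 4, 2.9-fold (0.46 log units) apart, beyond the scatter of two such steps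

The series therefore shows that the direction of the 4-chlorophenyl change carried over from one core to the other while its size did not, but it does not show why, and the two gaps come from the same four compounds, so they are one observation seen from two sides rather than two independent findings.

The compounds shown leave open how a longer chain such as phenylethyl, or a chain ending in an amine, would behave in place of benzyl on the amide-type nitrogen. Also open, from the compounds shown here alone, is whether a methyl or a bromomethyl on that carbonyl carbon would match chloromethyl in this assay.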